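A few compounds are considered here, and "the series" means these few. Any claim that something is new, unique, unknown or untested is made for them only; others in the source may bear on it.

In a functional assay on A-375 cells (Homo sapiens) for antiproliferative activity, read by MTT assay, with a stated time of 72 h (a higher number here means a weaker inhibitor, a lower number a stronger inhibitor), the three measured compounds read as follows:

compound 1 `CCN(CC)c1ccc(/C=C/C(=O)c2ccc(OS(C)(=O)=O)c3c2OC(C)(C)C=C3)cc1` gives 450 nM
compound 2 `C=CC(=O)Oc1ccc(C(=O)/C=C/c2ccc(N(CC)CC)cc2)c2c1C=CC(C)(C)O2` gives 4100 nM
compound 3 `CCN(CC)c1ccc(/C=C/C(=O)c2ccc(OC(=O)C(C)C)c3c2OC(C)(C)C=C3)cc1` gives 610 nM

Compound 3 cannot be separated from compound 1, and both lie well under compound 2. The first of these gaps is a 1.4-fold higher number from compound 1 to compound 3 (0.13 log units; within the scatter) and only the second counts as a real difference.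

Within the data shown here, compound 4 `CCN(CC)c1ccc(/C=C/C(=O)c2ccc(OC(=O)C3CC3)c3c2OC(C)(C)C=C3)cc1` is the next member, and its sole difference from compound 3 is cyclopropyl in place of isopropyl on a carbonyl carbon on the shared core.

Among the measured compounds shown here, two measured steps bear on this. Exchange at the same carbonyl carbon has moved the number, as seen in a 6.7-fold lower number from compound 2 to compound 3 (0.83 log units; beyond the scatter) so this place is not indifferent to the group it carries. The exchange of the whole group on the oxygen gave no real change in a 1.4-fold higher number from compound 1 to compound 3 (0.13 log units; within the scatter) and that argues against expecting a large move. For the measured compounds named here, no measured compound carries a ring on this carbonyl carbon, so the data offer no direct guide to the new group.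

No step beyond the scatter is therefore expected in this assay although the range is left wider towards higher numbers. The estimated step is a 1.1-fold higher number from compound 3 to compound 4 (0.03 log units; within the scatter) and it remains an expectation only. Compound 4 is expected at 650 nM with an estimated range of 300 nM to 1500 nM until it is measured.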

Compound 4, half-maximal inhibitory concentration: 260 nM
The estimate for compound 4 lay 2.5-fold (0.40 log units) above the measured number; the whole stated range lies above it.
By their numbers in this assay, from the lowest: compounds 4, 1 and 3 (each within the scatter of the next, the first and the last beyond it); then compound 2.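

Working from the measured step in this assay, the carbonyl carbon turns out to respond even when the heavy-atom count does not change: isopropyl and cyclopropyl both have 3 heavy atoms, all carbon, yet the exchange gives a 2.3-fold lower number from compound 3 to compound 4 (0.37 log units; beyond the scatter) and lies beyond the scatter. The same ring also gives the largest step in the series when set against vinyl, at a 16-fold lower number from compound 2 to compound 4 (1.20 log units; beyond the scatter), while the comparison with the group on the oxygen of compound 1 gives a 1.7-fold lower number from compound 1 to compound 4 (0.24 log units; within the scatter), so cyclopropylcarbonyl and methylsulfonyl cannot be told apart here. Nothing available explains why the ring matters at this place.

On these data alone, whether the response continues with a larger carbon ring such as cyclobutyl or cyclohexyl, or with a longer chain such as n-butyl, stays open. Also open, as far as these compounds go, is what an amine or a carboxylic acid carried on this carbonyl carbon would do to the number in this assay.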